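The compounds below may be only part of what the source reports. "The series", "measured", "known", "first", "only" and "open" are said of these compounds alone.

Compound 1 `COc1ccccc1/C=C/C(=O)/C=C/c1ccc(OCc2cn(CCCOc3cc(=O)oc4ccccc34)nn2)c(OC)c1` gives 53% in a functional assay on HCT-116 cells (Homo sapiens) for inhibition, read by sulforhodamine B assay, with a stated time of 48 h, tested at 50 uM; on this read-out higher numbers stand for more inhibition of growth at the one concentration tested and lower numbers for less inhibition of growth
Compound 2 `COc1cccc(/C=C/C(=O)/C=C/c2ccc(OCc3cn(CCCOc4cc(=O)oc5ccccc45)nn3)c(OC)c2)c1` gives 55%
Compound 3 `COc1ccc(/C=C/C(=O)/C=C/c2ccc(OCc3cn(CCCOc4cc(=O)oc5ccccc45)nn3)c(OC)c2)cc1` gives 54%

Compound 3 stands level with compound 1 and compound 2, the steps being a number 1 percentage points higher from compound 1 to compound 3 (within the scatter) and a number 1 percentage points lower from compound 2 to compound 3 (within the scatter). Compound 4 `COc1cc(/C=C/C(=O)/C=C/c2cccs2)ccc1OCc1cn(CCCOc2cc(=O)oc3ccccc23)nn1` differs from compound 3 by thiophen-2-yl in place of 4-methoxyphenyl on a double-bonded chain carbon bound to a double-bonded chain carbon, with thiophen-2-yl in place of 4-methoxyphenyl on a double-bonded chain carbon bound to a double-bonded chain carbon. The measured steps bear on this only loosely, since they change the methoxyphenyl group at that place and never replace it. For the measured compounds named here, with a number 2 percentage points higher from compound 1 to compound 2 (within the scatter) as the third of them, all are small, so no step beyond the scatter is expected in this assay, though no measured compound carries thiophen-2-yl. The expected step is a number 2 percentage points lower from compound 3 to compound 4 (within the scatter). Compound 4 is estimated at 52%, ranging from 40% to 64%.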

Compound 4, percent growth inhibition at one concentration: 58%
Compound 4: middle estimate off by 6 percentage points, on the low side; low and high end bracket the measured number.
By their numbers in this assay, from the lowest: compounds 1, 3, 2 and 4 (each within the scatter of the next).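

Thiophen-2-yl, a five-membered aromatic ring, can stand in place of each methoxyphenyl group on a double-bonded chain carbon bound to a double-bonded chain carbon with no change beyond the scatter in this assay (a number 4 percentage points higher from compound 3 to compound 4 (within the scatter); a number 3 percentage points higher from compound 2 to compound 4 (within the scatter); a number 5 percentage points higher from compound 1 to compound 4 (within the scatter)). The earlier compounds shown here only moved the methoxy group, whereas here the whole ring is exchanged and the read-out holds. Nothing available explains this result.

Going by these compounds, whether an amine or a carboxylic acid at this place would also hold the read-out stays open.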